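The source may hold more compounds than are shown below. What is called first, only, known or untested is meant among the compounds shown, and "the series" means these compounds.

Measured so far in a functional assay on CHO-K1 cells for agonist activity at Glucose-dependent insulinotropic receptor (Homo sapiens), read by HTRF and cAMP accumulation, with a stated time of 30 min; on this read-out lower numbers stand for smaller maximal responses and higher numbers for larger maximal responses:
compound 1 `CN(CCNc1ccc2c(c1)CCS2(=O)=O)C1CCN(C(=O)OC(C)(C)C)CC1` gives 10%
compound 2 `CC(C)(C)OC(=O)N1CCC(CCCNc2ccc3c(c2)C(=O)CCO3)CC1` gives 100%
compound 3 `COc1cnc(N2CCC(CCCNc3ccc4c(c3)OCC4=O)CC2)nc1` gives 101%

Compound 3 has the highest number of the three. Its nearest neighbour is compound 2, which lies within the scatter of it, so the two cannot be told apart on this read-out. Compound 1 is furthest away, beyond the scatter, with a markedly smaller maximal response than compound 3.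

The next compound in the series is compound 4 `CC(C)c1nsc(N2CCC(CCCNc3ccc4c(c3)OCC4=O)CC2)n1`. It differs from compound 3 in one place: 3-isopropyl-1,2,4-thiadiazol-5-yl in place of 5-methoxypyrimidin-2-yl on an amine nitrogen in a ring

Among the compounds with values here, no pair of measured compounds isolates this change, so its effect cannot be read off directly. What the measured compounds do show is that compound 2 and compound 3, which carry different groups on this ring nitrogen, give values within the scatter of each other; the group on that nitrogen has so far not moved the maximal response in this assay. On that basis a step no larger than the scatter is expected from compound 3 to compound 4, with no clear direction. Compound 4 is therefore estimated to reach 95%, with a range from 75% to 105%. The step of a number 6 percentage points lower from compound 3 to compound 4 (within the scatter) is expected to fall within the usual scatter.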

Compound 4, largest response reached (Emax), in percent of the reference or control that the assay uses: 10%
Estimate against measurement, compound 4: 85 percentage points above; the measured number lies below the stated range.
By their numbers in this assay, from the lowest: compounds 1 and 4 (each within the scatter of the next); then compounds 2 and 3 (each within the scatter of the next).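

In this assay the amine nitrogen in the ring is a sensitive place in this series: with 3-isopropyl-1,2,4-thiadiazol-5-yl in place of 5-methoxypyrimidin-2-yl, the response falls by a number 91 percentage points lower from compound 3 to compound 4 (beyond the scatter), a step beyond the scatter on an otherwise unchanged compound. The two groups have the same counts of heavy atoms, hydrogen-bond donors and hydrogen-bond acceptors, and neither carries a net charge, so these counts do not separate compound 3 at 101% from compound 4 at 10%. No measurement at hand gives a cause for this step.

The change replaces a six-membered aromatic ring with a five-membered one, brings in sulfur, and swaps methoxy for isopropyl all at once, so the shown compounds do not tell which of these parts goes with the lower response. As far as these compounds go, a 5-isopropylpyrimidin-2-yl or a 3-methoxy-1,2,4-thiadiazol-5-yl group on this ring nitrogen would separate the aromatic ring from its substituent, and the outcome for either group remains open.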